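Phenyl for Ethoxycarbonyl on Two Imine Cores

A few compounds are considered here, and "the series" means these few. Any claim that something is new, unique, unknown or untested is made for them only; others in the source may bear on it.

Compound 1 `CCOC(=O)/C=N/c1cnc(Nc2ccc(N3CCN(C)CC3)cc2)nc1NC1CCCC1` gives 17000 nM in a functional assay on HCT-116 cells (Homo sapiens) for antiproliferative activity, read by MTT assay; on this read-out higher numbers stand for weaker inhibition and lower numbers for stronger inhibition. Compound 2 `CN1CCN(c2ccc(Nc3ncc(/N=C/c4ccccc4)c(NC4CCCC4)n3)cc2)CC1` differs from it by phenyl in place of ethoxycarbonyl on a carbon with a double bond to nitrogen and in this assay compound 2 gives 35200 nM; the step is a 2.1-fold higher number from compound 1 to compound 2 (0.32 log units; beyond the scatter). Compound 3 `CCOC(=O)/C=N/c1cnc(Nc2ccc(S(N)(=O)=O)cc2)nc1NC(C)C` sits on a second core, and the difference between the two cores is not broken down here. In this assay compound 3 gives 49100 nM. Compound 4 `CC(C)Nc1nc(Nc2ccc(S(N)(=O)=O)cc2)ncc1/N=C/c1ccccc1` is not yet measured; it differs from compound 3 by phenyl in place of ethoxycarbonyl on a carbon with a double bond to nitrogen, the same change as between compound 1 and compound 2 at the same place. Going by the values given here, for compound 4 the step expected in this assay is a 2.0-fold higher number from compound 3 to compound 4 (0.31 log units; beyond the scatter), resting on the single earlier instance a 2.1-fold higher number from compound 1 to compound 2 (0.32 log units; beyond the scatter) and set beside it in the same direction. Compound 4 is therefore estimated at 100000 nM, expected to fall between 40000 nM and 250000 nM.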

Compound 4, half-maximal inhibitory concentration: > 100000 nM
Compound 4: no number, only a limit; the forecaster's own chance of this, stated with the estimate: 30%; the middle value sits exactly at the limit.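

In this assay compound 4 gives > 100000 nM, which is a limit of the assay and not a number. Phenyl in place of ethoxycarbonyl on the second core gives an at least 2.0-fold higher number from compound 3 to compound 4 (0.30 log units; that floor lies within the scatter), so this step is a floor and its true size is unknown. The direction seen on the core of compound 1 is not contradicted on the core of compound 3, but whether the size of the step carries over is not shown: the same change on two cores in this assay, a 2.1-fold higher number (0.32 log units; beyond the scatter) from compound 1 to compound 2 and an at least 2.0-fold higher number (0.30 log units; that floor lies within the scatter) from compound 3 to compound 4; the limit leaves it open whether they differ

Going by these compounds alone, only two pairs bear on this change, and one of them ends in a limit, so its behaviour on further cores remains open. Also open, going by these compounds, is how other groups on a carbon with a double bond to nitrogen, such as a carboxylic acid or an amine, would read in this assay.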